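This account rests on a few compounds, and the source may have more. Where it says the series, first, only, none or still open, it means among the compounds named here.

Two compounds anchor the comparison. Compound 1, `COc1cc(OCc2csc(-c3cccc(C(=O)N(C)C)c3)n2)c2cc(-c3cn4nc(OC)sc4n3)oc2c1`, gives 0.8 nM in a functional assay on HEK293 cells for antagonist activity at proteinase-activated receptor 4 (Homo sapiens), read by FLIPR and calcium flux, with a stated time of 30 min; a higher number here means a weaker inhibitor, a lower number a stronger inhibitor. Compound 2, `CNC(=O)c1ccc(-c2nc(COc3cc(OC)cc4oc(-c5cn6nc(OC)sc6n5)cc34)cs2)cc1`, gives 0.4 nM in this assay. Between them, a 2.0-fold lower number from compound 1 to compound 2 (0.30 log units; within the scatter). On the two numbers shown, compound 2 carries the smaller one, but its only neighbour, compound 1, sits within the scatter of it, so the two cannot be ranked.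

Compound 3, `COc1cc(OCc2csc(-c3ccc(S(C)(=O)=O)cc3)n2)c2cc(-c3cn4nc(OC)sc4n3)oc2c1`, has not yet been measured. It differs from compound 2 in one place: methylsulfonyl in place of methylcarbamoyl on an aromatic carbon. Among the compounds with values here, no measured pair shows this exchange. Within the data shown here, the only measured step, a 2.0-fold lower number from compound 1 to compound 2 (0.30 log units; within the scatter), concerns a different alteration of the same phenyl group and moved the number within the scatter, which shows only that one change at that phenyl group has so far been tolerated; it says nothing about exchanging the methylcarbamoyl group itself. Compound 3 is therefore expected to stay close to its neighbour, with room for a modest drift toward a higher number. The step expected for compound 3 is a 2.5-fold higher number from compound 2 to compound 3 (0.40 log units; beyond the scatter). Compound 3 is estimated to give 1 nM in this assay, within 0.3 nM to 4 nM.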

Compound 3, half-maximal inhibitory concentration: 0.8 nM
The estimate for compound 3 lay 1.3-fold (0.10 log units) above the measured number; the measured number falls inside the stated range.
By their numbers in this assay, from the lowest: compounds 2, 1 and 3 (each within the scatter of the next).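

In this assay the exchange at this position, para to a large group, gives a 2.0-fold higher number from compound 2 to compound 3 (0.30 log units; within the scatter) and so reaches beyond the earlier change in the phenyl group: the whole methylcarbamoyl group, with its hydrogen-bond donor, gives way to methylsulfonyl, which has 0 hydrogen-bond donors, without a difference that can be read. The comparison with the other amide gives the same reading, with no change at the digits printed from compound 1 to compound 3 (within the scatter) on going from 3-(dimethylcarbamoyl)phenyl to 4-(methylsulfonyl)phenyl, so all three compounds now stand within the scatter of one another and this position has accepted both carbonyl-based and sulfur-based groups. The compounds shown offer no independent measurement that could explain this tolerance.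

On these data alone, all three groups carry no net charge and remain short, so it stays open how the number would respond to an amine or a carboxylic acid on the phenyl ring, or to a longer chain in place of the methyl on the sulfonyl group. As far as these compounds go, it also stays open whether the same tolerance would hold on a different core, as the shared core is the same in all three compounds.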